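Removing the Ethoxy Group from a Bromo Chromone Amide

The source may hold more compounds than are shown below. What is called first, only, known or untested is meant among the compounds shown, and "the series" means these compounds.

The measured compounds and their values:
compound 1, `Cc1cccc(C(=O)Nc2cccc3c(=O)cc(C(=O)O)oc23)c1`, gives 2750 nM in an assay on CHO cells for agonist activity at G protein-coupled receptor GPR35 (Rattus norvegicus), read by a beta-galactosidase reporter and beta-arrestin recruitment, with a stated time of 90 min; on this read-out lower numbers stand for an effect already at smaller amounts and higher numbers for an effect only at larger amounts of compound
compound 2, `CCOc1ccc(C(=O)Nc2cc(Br)cc3c(=O)cc(C(=O)O)oc23)cc1`, gives 1360 nM in this assay
compound 3, `CCCOc1ccc(C(=O)Nc2cccc3c(=O)cc(C(=O)O)oc23)cc1`, gives 3610 nM in this assay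

Among these three numbers in this assay, compound 2 stands lowest. Its nearest neighbour is compound 1, whose number is higher by a step beyond the usual scatter, and its furthest is compound 3, higher still and also beyond the scatter.

The unmeasured compound 4, `O=C(Nc1cc(Br)cc2c(=O)cc(C(=O)O)oc12)c1ccccc1`, differs from compound 2 in one place: hydrogen in place of ethoxy on an aromatic carbon. Among the measured compounds shown here, compound 1 and compound 3 both lack the bromine of compound 2 and both carry a different group on the amide-bearing ring, so no measured pair isolates this change. The data therefore offer no direct guide to its size.

On that basis only a cautious expectation is possible. Compound 4 is expected to give about 2500 nM in this assay, within a range from 1000 nM to 6500 nM. This estimate for compound 4 amounts to a step of a 1.8-fold higher number from compound 2 to compound 4 (0.26 log units; within the scatter), a modest rise that may well fall within the scatter.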

Compound 4, half-maximal effective concentration: 2750 nM
For compound 4 the middle estimate is 1.1-fold (0.04 log units) below the measured one, within the range that was stated.
By their numbers in this assay, from the lowest: compound 2; then compounds 1, 4 and 3 (each within the scatter of the next).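

Among the compounds shown here, compound 4 keeps the bromine of compound 2, so the change from 4-ethoxyphenyl to phenyl gives the first step in this assay that turns on one place alone: a 2.0-fold higher number from compound 2 to compound 4 (0.31 log units; beyond the scatter), a modest step that lies beyond the scatter. The ethoxy group on this aromatic carbon, para to a large group, therefore counts for something here, yet its removal does not end the response, as compound 4 still gives 2750 nM. The material at hand offers no measured finding that would account for the size of this step.

The compounds shown leave open whether a methoxy group, a longer chain such as butoxy, or an amine on this same carbon would give a number nearer that of compound 2 or that of compound 4. They also leave open whether hydrogen in place of ethoxy would give a step of similar size on the core without the bromine, and what the bromine itself contributes.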